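Opening a ring amide to an aminoethyl amide

A few compounds are considered here, and "the series" means these few. Any claim that something is new, unique, unknown or untested is made for them only; others in the source may bear on it.

Of the compounds shown here, two of a shared core have been measured in an assay on HEK293 cells for displacement of a labelled ligand from NPC1-like intracellular cholesterol transporter 1 (Homo sapiens); a higher number here means a weaker inhibitor, a lower number a stronger inhibitor. Compound 1 `CCC1CCCN(C(=O)CN2CN(c3ccccc3)C3(CCN(C(=O)c4ccc(C5CCCCC5)cc4)CC3)C2=O)C1` gives 2600 nM in this assay. Among the measured compounds shown here, compound 2 `CS(=O)(=O)N1CCN(C(=O)CN2CN(c3ccccc3)C3(CCN(C(=O)c4ccc(C5CCCCC5)cc4)CC3)C2=O)CC1` gives 6300 nM in this assay, the higher of the two numbers; the only measured step, a 2.4-fold higher number from compound 1 to compound 2 (0.38 log units; beyond the scatter), separates it from compound 1, and it is modest but beyond the scatter. Compound 3 `NCCNC(=O)CN1CN(c2ccccc2)C2(CCN(C(=O)c3ccc(C4CCCCC4)cc3)CC2)C1=O` has not yet been measured. It differs from compound 2 in one place: (2-aminoethyl)amino in place of 4-(methylsulfonyl)piperazin-1-yl on a carbonyl carbon. The ring amine at the carbonyl carbon is thus replaced by an open two-carbon chain carrying a free amine. For the measured compounds named here, no measured step covers this kind of exchange; the one step in hand, from compound 1 to compound 2, swaps one six-membered ring amine for another and moved the number only modestly. On that thin basis the step of a 1.3-fold lower number from compound 2 to compound 3 (0.10 log units; within the scatter) is expected to stay small, with no confident direction. For compound 3 the estimate in this assay is 5000 nM, within a range of 1500 nM to 16000 nM.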

Compound 3, half-maximal inhibitory concentration: 3800 nM
Estimate against measurement, compound 3: 1.3-fold (0.12 log units) above; measured number inside the range.
By their numbers in this assay, from the lowest: compounds 1, 3 and 2 (each within the scatter of the next, the first and the last beyond it).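

In this assay, the open (2-aminoethyl)amino group on the carbonyl carbon gives a number that cannot be told apart from those of either ring amine: a 1.7-fold lower number from compound 2 to compound 3 (0.22 log units; within the scatter) and a 1.5-fold higher number from compound 1 to compound 3 (0.16 log units; within the scatter). Among the three compounds shown, a ring at this position is therefore not needed to stay in this range, even though the entering group has fewer heavy atoms than 4-(methylsulfonyl)piperazin-1-yl, and 2 hydrogen-bond donors against 0. No measurement here offers any explanation of this tolerance.

Compound 3 changes ring, size and donor count in a single exchange, so the three compounds cannot show whether any one of these matters on its own, or whether the free amine contributes at all. A 2-hydroxyethyl amide, a longer 3-aminopropyl chain or a terminal carboxylic acid on the same carbonyl carbon could separate the role of the amine from that of the open chain, and could show whether this position can move the number further than the small steps seen so far.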